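From compound 2 to compound 3: a new carbonyl substituent

This account rests on a few compounds, and the source may have more. Where it says the series, first, only, none or still open, it means among the compounds named here.

Measured in a functional assay on HepG2 cells (Homo sapiens) for antiproliferative activity, read by MTT assay, with a stated time of 48 h; a lower number here means a stronger inhibitor, a higher number a weaker inhibitor:
- Compound 1 `CCn1c(C(=O)NCCN)ccc1C(CC)(CC)c1ccc(OCCC(O)(CC)CC)c(C)c1`: 1590 nM
- Compound 2 `C#CCCOC(=O)c1ccc(C(CC)(CC)c2ccc(OCCC(O)(CC)CC)c(C)c2)n1CC`: > 50000 nM (a limit)

Compound 2 reads > 50000 nM, which is a limit of the assay and not a number. Among the compounds with values here, the one measured step that bears on the next change is an at least 31-fold higher number from compound 1 to compound 2 (1.49 log units; beyond the scatter), seen when (but-3-yn-1-yl)oxy took the place of (2-aminoethyl)amino on a carbonyl carbon. This step is large and lies beyond the scatter.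

Compound 3 `CCn1c(C(=O)Nc2ccc(OC(F)(F)F)cc2)ccc1C(CC)(CC)c1ccc(OCCC(O)(CC)CC)c(C)c1` keeps the shared core and changes that same place: (4-(trifluoromethoxy)phenyl)amino in place of (but-3-yn-1-yl)oxy on a carbonyl carbon. As in compound 1, an amino group now sits on the carbonyl carbon, but this one carries an aromatic ring instead of a chain. Within the data shown here, no measured compound shows what that ring does.

Among the measured compounds shown here, a large move towards a lower number is therefore expected in this assay, resting on the single step of an at least 31-fold higher number from compound 1 to compound 2 (1.49 log units; beyond the scatter), with the outcome uncertain. The expected step is an at least 8.3-fold lower number from compound 2 to compound 3 (0.92 log units; beyond the scatter). For compound 3 the estimated value is 6000 nM, within an expected range of 1500 nM to 25000 nM.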

Compound 3, half-maximal inhibitory concentration: > 50000 nM
Compound 3: no number, only a limit; the forecaster's own chance of this, stated with the estimate: 15%; middle value at least 8.3-fold (0.92 log units) away from the limit.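

In this assay compound 3 gives > 50000 nM, which is a limit of the assay and not a number. Against compound 1, with 4-(trifluoromethoxy)phenyl in place of 2-aminoethyl on an amide-type nitrogen, the comparison gives an at least 31-fold higher number from compound 1 to compound 3 (1.49 log units; beyond the scatter), while the step that joins compound 2 and compound 3 cannot be read, with a limit on both sides. Compound 2 alone could not show it, but an amino group on the carbonyl carbon is clearly not enough by itself to give a measurable value here: compound 1 and compound 3 both carry one, and only compound 1 gives a number, so what sits on that nitrogen matters as well.

Any difference in strength between compound 2 and compound 3 stays hidden, as both rest on the same ceiling: the limit of > 50000 nM in this assay, at which 2 of the 3 values shown sit.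

On these data alone, it also stays open which feature of the 2-aminoethyl chain counts, and a plain propyl chain, a longer chain ending in an amine, or an unsubstituted phenyl ring on that nitrogen would each bear on this question.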